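Replacing the hydroxyphenyl of compound 1 with an azetidine

The compounds below may be only part of what the source reports. "The series", "measured", "known", "first", "only" and "open" are said of these compounds alone.

Measured compounds:
compound 1, `Oc1ccc(CNc2cc(C(F)(F)F)cc3[nH]ncc23)cc1`: 91%
compound 2, `Oc1ccc(CNc2cc(C(F)(F)F)cc3[nH]ncc23)c(Cl)c1`: 97%
compound 3, `O=C1NCc2c(NCc3ccccc3[N+](=O)[O-])cccc21`: 29%

In an assay for inhibition of Tryptophan 2,3-dioxygenase (Homo sapiens), with stated times of 10 min and 60 min, tested at 100 uM (on this read-out higher numbers stand for a stronger effect at the one concentration tested and lower numbers for a weaker effect), compound 1 gives 91%, the second highest of the three numbers. Its nearest neighbour is compound 2, where a number 6 percentage points higher from compound 1 to compound 2 (within the scatter); the furthest is compound 3, whose value of 29% lies beyond the scatter and belongs to a different core.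

Compound 4, `FC(F)(F)c1cc(NCC2CNC2)c2cn[nH]c2c1`, is not yet measured. It differs from compound 1 as follows: azetidin-3-yl in place of 4-hydroxyphenyl on a saturated chain carbon bound to a nitrogen on an aromatic ring. For the measured compounds named here, no measured step touches this change: the one measured step alters the 4-hydroxyphenyl by a chloro substituent rather than removing it, and it stays within the scatter. The step to compound 4 removes the aromatic group entirely, so nothing in the measured pairs predicts its size. The account therefore expects a drop for compound 4 in this assay, of uncertain size, a number 41 percentage points lower from compound 1 to compound 4 (beyond the scatter). Compound 4 is estimated at 50%, within a range from 15% to 85%.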

Compound 4, a percentage reported as inhibition, at one concentration (the size of the read-out at that concentration, not a potency): 49%
Beside the measured number, compound 4's estimate is 1 percentage points above it; the measured number falls inside the stated range.
By their numbers in this assay, from the lowest: compound 3; then compound 4; then compounds 1 and 2 (each within the scatter of the next).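

In this assay, azetidin-3-yl in place of 4-hydroxyphenyl on a saturated chain carbon bound to a nitrogen on an aromatic ring gives a number 42 percentage points lower from compound 1 to compound 4 (beyond the scatter). For the compounds shown here, the only earlier step at the hydroxyphenyl group, a chloro in place of hydrogen, gave a number 6 percentage points higher from compound 1 to compound 2 (within the scatter), so this is the first sign that the read-out depends on the group carried at this position. Nothing available explains the size of this step.

The compounds shown leave open whether a plain phenyl, a cyclohexyl or a piperidine on the same chain carbon would read like compound 1 or like compound 4. They also leave open how a methoxy in place of the hydroxyl of compound 1 would read.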